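This account rests on a few compounds, and the source may have more. Where it says the series, first, only, none or still open, it means among the compounds named here.

Measured compounds:
compound 1 `CN(C)C(=O)c1cc(-c2cnc(NCc3c(F)ccc4c3CCO4)c3cn[nH]c(=O)c23)n(C)n1` gives 3000 nM in a physicochemical assay for solubility, read by LC-MS, in phosphate buffer, with a stated time of 24 h, at pH 7.4; on this read-out higher numbers stand for higher solubility and lower numbers for lower solubility;
compound 2 `CNC(=O)c1cc(-c2cnc(NCc3c(F)ccc4c3CCO4)c3cn[nH]c(=O)c23)n(C)n1` gives 7000 nM;
compound 3 `Fc1ccc2c(c1CNc1ncc(Oc3ccccc3)c3nncn13)CCO2` gives 8000 nM.

Compound 2 sits close to compound 3, the two values falling within the scatter of each other, while the step of a 2.3-fold higher number from compound 1 to compound 2 (0.37 log units; beyond the scatter) sets it apart from compound 1. Compound 4 `CNC(=O)c1ncc(-c2cnc(NCc3c(F)ccc4c3CCO4)c3cn[nH]c(=O)c23)n1C` differs from compound 2 by 1-methyl-2-(methylcarbamoyl)-1H-imidazol-5-yl in place of 1-methyl-3-(methylcarbamoyl)-1H-pyrazol-5-yl on an aromatic carbon. Going by the values given here, none of the measured steps covers a change of this kind: the one measured step exchanges hydrogen for methyl on the amide nitrogen, a different place and a different sort of change. Among the compounds with values here, with no step to rest on, the number for compound 4 is expected to differ from that of compound 2 by no more than the scatter, no change at the digits printed from compound 2 to compound 4 (within the scatter). Compound 4 is therefore estimated at 7000 nM, with a range from 3000 nM to 16000 nM.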

Compound 4, solubility: 5000 nM
Beside the measured number, compound 4's estimate is 1.4-fold (0.15 log units) above it, within the range that was stated.
By their numbers in this assay, from the lowest: compounds 1, 4, 2 and 3 (each within the scatter of the next, the first and the last beyond it).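

In this assay, placing 1-methyl-2-(methylcarbamoyl)-1H-imidazol-5-yl on this aromatic carbon in place of the pyrazole group, with the same atoms joined differently, gives a 1.4-fold lower number from compound 2 to compound 4 (0.15 log units; within the scatter) and so shows no change that can be told from the scatter. Set against 3-(dimethylcarbamoyl)-1-methyl-1H-pyrazol-5-yl, the same group gives a 1.7-fold higher number from compound 1 to compound 4 (0.22 log units; within the scatter) and is again not separated. No available measurement offers an explanation for either step. The compounds shown leave open how a dimethylcarbamoyl group on the imidazole would read. They also leave open whether a carboxylic acid there would move the number beyond the scatter.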